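The compounds below may be only part of what the source reports. "The series", "measured", "known", "first", "only" and "open" are said of these compounds alone.

Working notes on the series. In a functional assay on NB-4 cells (Homo sapiens) for cytotoxicity, read by CCK-8 assay, with a stated time of 24 h (on this read-out higher numbers stand for weaker inhibition and lower numbers for stronger inhibition), compound 1 (`C=CC(=O)N1C(=O)CC(c2ccc(Cl)cc2)Sc2ccccc21`) gives 22600 nM, compound 2 (`C=CC(=O)N1C(=O)CC(c2ccccc2C(F)(F)F)Sc2ccccc21`) gives 35200 nM and compound 3 (`C=CC(=O)N1C(=O)CC(c2cccc(Cl)c2)Sc2ccccc21`) gives 31700 nM. Compound 3 lies within the scatter of both other compounds, so the three values do not separate. Compound 4 (`C=CC(=O)N1C(=O)CC(c2ccccc2)Sc2ccccc21`) has hydrogen in place of chloro on an aromatic carbon, that is, 3-chlorophenyl becomes phenyl: hydrogen in place of chloro on an aromatic carbon. Among the measured compounds shown here, no measured pair shows the removal of a group from this ring, so the evidence is indirect. The nearest measured change is 3-chlorophenyl in place of 4-chlorophenyl, a 1.4-fold higher number from compound 1 to compound 3 (0.15 log units; within the scatter), which stays within the scatter. Set against compound 3, compound 2, which carries a trifluoromethyl group, gives 35200 nM, a value also within the scatter. No step beyond the scatter is therefore expected, and no direction can be assigned. The estimated change is a 1.1-fold lower number from compound 3 to compound 4 (0.02 log units; within the scatter). The expected value for compound 4 is 30000 nM, with an estimated range from 15000 nM to 60000 nM.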

Compound 4, half-maximal inhibitory concentration: 35500 nM
Estimate against measurement, compound 4: 1.2-fold (0.07 log units) below; the measured number falls inside the stated range.
By their numbers in this assay, from the lowest: compounds 1, 3, 2 and 4 (each within the scatter of the next).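

Among the compounds shown here, compound 4 is the only compound here with no substituent on this aromatic ring, and in this assay it does not separate from the substituted compounds: hydrogen in place of chloro gives a 1.1-fold higher number from compound 3 to compound 4 (0.05 log units; within the scatter) and a 1.6-fold higher number from compound 1 to compound 4 (0.20 log units; within the scatter) while hydrogen in place of trifluoromethyl gives a 1.0-fold higher number from compound 2 to compound 4 (0.00 log units; within the scatter) with no step leaving the scatter. Across these four compounds, therefore, neither chloro, in either placement, nor trifluoromethyl is shown to be required for the read-out. No available evidence bears on the reason for this result.

Going by these compounds, whether any group on this ring can move the number beyond the scatter stays open, and an amine, a carboxylic acid or a longer chain here would test that. Every compound shown keeps the shared core unchanged, so what each part of that core contributes also stays open.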